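The source may report more compounds than this note shows. Statements on the series, on what has been measured and on what is new or still open speak of the compounds shown alone.

Measured in a functional assay on DU-145 cells (Homo sapiens) for inhibition, read by trypan blue exclusion, with a stated time of 96 h; on this read-out lower numbers stand for stronger inhibition of growth and higher numbers for weaker inhibition of growth:
compound 1 `O=C(/C(=C\c1ccccc1OCc1ccccc1)SCc1ccc(F)cc1)c1ccc(Cl)cc1` gives 1000 nM
compound 2 `COc1ccc(S/C(=C/c2ccccc2OCc2ccccc2)C(=O)c2ccc(Cl)cc2)cc1` gives 1000 nM

Among the compounds with values here, compound 2 stands level with compound 1 at the digits given, and compound 1 is its only measured neighbour. Compound 3 `Cc1ccc(CS/C(=C/c2ccccc2OCc2ccccc2)C(=O)c2ccc(Cl)cc2)cc1` is not yet measured. It has 4-methylbenzyl in place of 4-methoxyphenyl on a sulfur, and the counted difference reads 4-methylbenzyl in place of 4-methoxyphenyl on a sulfur with the change placed on the sulfur whose other neighbour is the double-bonded chain carbon.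

Within the data shown here, one measured step bears on this position: no change at the digits printed from compound 1 to compound 2 (within the scatter) with 4-methoxyphenyl in place of 4-fluorobenzyl on that same sulfur. It lies within the scatter, so neither a benzyl nor a phenyl group on the sulfur stands apart so far. Among the measured compounds shown here, that is thin evidence, as it rests on a single pair, and no measured compound carries 4-methylbenzyl.

No step beyond the scatter is therefore expected in this assay for this change. The expected size is no change at the digits printed from compound 2 to compound 3 (within the scatter) and no direction is favoured. For compound 3 the estimated value is 1000 nM with an expected range from 400 nM to 2500 nM on this read-out.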

Compound 3, concentration for 50% growth inhibition: 1000 nM
The estimate for compound 3 equals the measured number at the digits printed; the range from low to high includes it.
By their numbers in this assay, from the lowest: compounds 1, 2 and 3 (each within the scatter of the next).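

In this assay, 4-methylbenzyl in place of 4-methoxyphenyl on the sulfur whose other neighbour is the double-bonded chain carbon gives no change at the digits printed from compound 2 to compound 3 (within the scatter), so the all-carbon group and the oxygen-bearing group cannot be told apart on this read-out. Compound 3 also gives the series its first change on the benzyl ring itself, as methyl in place of fluoro on an aromatic carbon gives no change at the digits printed from compound 1 to compound 3 (within the scatter), and the three compounds now read as a flat set across these sulfur substituents. No measurement in hand accounts for this flat result.

Since the rest of the shared core stays fixed in all three compounds, these pairs show only that the substituents tried on this sulfur do not separate in this assay, not whether the core itself carries the growth inhibition. From the compounds shown here alone, whether a markedly different group on that sulfur, such as a carboxylic acid, a morpholine or a longer alkyl chain, would move the value beyond the scatter remains open.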